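The compounds below may be only part of what the source reports. "The series", "measured", "known", "first", "only" and "open" are said of these compounds alone.

In a functional assay on A549 cells (Homo sapiens) for inhibition, read by CCK-8 assay, with a stated time of 72 h, tested at 10 uM (a higher number here means more inhibition of growth at the concentration tested, a lower number less inhibition of growth), compound 3 `COc1cccc(NC(=O)C2(C(=O)Nc3ccc(Nc4ncc5cc(C(=O)N(C)C)n(C6CCCC6)c5n4)cc3)CC2)c1` gives 96% and sits level, within the scatter, with compound 1 `CN(C)C(=O)c1cc2cnc(Nc3ccc(NC(=O)C4(C(=O)Nc5ccc(Br)cc5)CC4)cc3)nc2n1C1CCCC1` at 90.3% on the same read-out. Compound 2 `CN(C)C(=O)c1cc2cnc(Nc3ccc(NC(=O)C4(C(=O)Nc5cccc(C#N)c5)CC4)cc3)nc2n1C1CCCC1` gives 73.6%, leaving a number 22.4 percentage points higher from compound 2 to compound 3 (beyond the scatter) as the gap. Compound 4 `CN(C)C(=O)c1cc2cnc(Nc3ccc(NC(=O)C4(C(=O)Nc5ccc(O)cc5)CC4)cc3)nc2n1C1CCCC1`, not yet measured, carries 4-hydroxyphenyl in place of 3-methoxyphenyl on an amide-type nitrogen in comparison with compound 3. Two earlier exchanges at this place bear on it: a number 5.7 percentage points higher from compound 1 to compound 3 (within the scatter) and a number 16.7 percentage points lower from compound 1 to compound 2 (beyond the scatter). Neither involves a hydroxy group, so they give only a rough guide to size. The expected change is a number 14 percentage points lower from compound 3 to compound 4 (beyond the scatter), a modest fall, though a step within the scatter remains possible. For compound 4 the estimated value is 82%, with an expected range from 60% to 97%.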

Compound 4, percent growth inhibition at one concentration: 94.4%
Beside the measured number, compound 4's estimate is 12.4 percentage points below it, and the stated range covers the measured number.
By their numbers in this assay, from the lowest: compound 2; then compounds 1, 4 and 3 (each within the scatter of the next).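

In this assay the swap from 3-methoxyphenyl to 4-hydroxyphenyl on the amide-type nitrogen gives a number 1.6 percentage points lower from compound 3 to compound 4 (within the scatter) and so costs nothing measurable, even though the entering group adds a hydrogen-bond donor. Hydroxy in place of bromo gives a number 4.1 percentage points higher from compound 1 to compound 4 (within the scatter) and is also level, so three quite different groups sit together here. Only the 3-cyanophenyl compound stands apart, with a number 20.8 percentage points higher from compound 2 to compound 4 (beyond the scatter) as the step.

On these data alone, whether 3-hydroxyphenyl, or an amine or a carboxylic acid on this ring, would hold the number stays open. No measured evidence explains these numbers.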